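The source may hold more compounds than are shown below. What is called first, only, known or untested is meant among the compounds shown, and "the series" means these compounds.

Among the measured compounds shown here, compound 3 `CCCCNc1nc(SC(C)C)nc2ncccc12` shows the lowest of the three numbers so far in a functional assay on T-24 cells (Homo sapiens) for cytotoxicity, read by neutral red uptake, with a stated time of 72 h (a higher number here means a weaker inhibitor, a lower number a stronger inhibitor), where compound 3 gives 12300 nM. Compound 1 `CCCCNc1nc(NCCCC)c2ccccc2n1` gives 19300 nM in this assay, and compound 2 `CCCCNc1nc(SCC)nc2ncccc12` gives 20900 nM; both sit within the scatter of compound 3, so the three cannot be ranked. For the measured compounds named here, the single measured step, a 1.7-fold lower number from compound 2 to compound 3 (0.23 log units; within the scatter), alters the sulfur-bound chain, not the chain that changes next. Compound 4 `CCCCCCCNc1nc(SC(C)C)nc2ncccc12` differs from compound 3 by propyl in place of hydrogen on a saturated chain carbon, four bonds along the chain from a nitrogen on an aromatic ring. Going by the values given here, no measured step touches this place, and the one step that exists stayed within scatter. The step from compound 3 to compound 4 is therefore expected to be small: a 1.4-fold lower number from compound 3 to compound 4 (0.14 log units; within the scatter). Compound 4 is estimated at 9000 nM, with a range from 2500 nM to 30000 nM.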

Compound 4, half-maximal inhibitory concentration: 8000 nM
For compound 4 the middle estimate is 1.1-fold (0.05 log units) above the measured one, and the stated range covers the measured number.
By their numbers in this assay, from the lowest: compounds 4, 3, 1 and 2 (each within the scatter of the next, the first and the last beyond it).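

Among the compounds shown here, no earlier step touched this place, and in this assay putting propyl in place of hydrogen on the saturated chain carbon gives a 1.5-fold lower number from compound 3 to compound 4 (0.19 log units; within the scatter). The two compounds therefore cannot be told apart, so this place accepts the longer chain without a shift that stands clear of the scatter. Nothing measured here accounts for how close the two numbers lie. Open, on these data alone, is whether a chain longer still, or one ending in an amine or a carboxylic acid, would move the number beyond the scatter.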